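The compounds below may be only part of what the source reports. "The series", "measured", "known", "first", "only" and "open" are said of these compounds alone.

In an ADME assay on microsomes from liver (Rattus norvegicus) for metabolic stability, read by LC-MS, using NADPH, at 37 degrees C (a higher number here means that the compound lasts longer, a lower number that the compound disappears faster), compound 1 (`Cc1oc(-c2ccc(Cl)cc2)nc1CN1CCC(C(=O)NCCCN2C[C@H](C)C[C@H](C)C2)CC1`) gives > 0.5 h. That value is a limit of the assay and not a number. Differing from compound 1 in more than one place, compound 2 (`Cc1ccccc1-c1nc(CN2CCC(C(=O)NCCCN3CCCC(CC(C)C)C3)CC2)c(C)o1`) gives 0.0383 h in this assay. Compound 3 (`Cc1oc(-c2c(Cl)cccc2Br)nc1CN1CCC(C(=O)NCCCN2C[C@H](C)C[C@H](C)C2)CC1`) has 2-bromo-6-chlorophenyl in place of 4-chlorophenyl on an aromatic carbon of the five-membered aromatic ring: 2-bromo-6-chlorophenyl in place of 4-chlorophenyl on an aromatic carbon. Within the data shown here, no measured pair shows what this change does, so only a small downward move, close to the usual scatter, is expected: an at least 1.2-fold lower number from compound 1 to compound 3 (0.09 log units; that floor lies within the scatter). For compound 3 the estimated half-life is 0.4 h, with an expected range from 0.12 h to 0.9 h.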

Compound 3, half-life: 0.0233 h
Beside the measured number, compound 3's estimate is 17-fold (1.23 log units) above it; measured number outside the range, below it.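

On this aromatic carbon of the five-membered aromatic ring, the replacement of 4-chlorophenyl by 2-bromo-6-chlorophenyl is the first single change shown, and in this assay it brings an at least 21-fold lower number from compound 1 to compound 3 (1.33 log units; beyond the scatter). The group carried here therefore matters strongly for how long the compound lasts. Compound 1 gives a limit and not a number, so the step has no fixed size: the limit of > 0.5 h in this assay, at which 1 of the 3 values shown sits.

Going by these compounds, whether the added bromine or the changed place of the chlorine carries the step stays open. So does the half-life with a plain phenyl on this carbon.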